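Swapping the Naphthyl Group for a Chlorophenyl Ring

A few compounds are considered here, and "the series" means these few. Any claim that something is new, unique, unknown or untested is made for them only; others in the source may bear on it.

Measured compounds in a functional assay on 786-0 cells (Homo sapiens) for inhibition, read by sulforhodamine B assay, with a stated time of 48 h, tested at 10 uM; a lower number here means less inhibition, a higher number more inhibition at the concentration tested (going by the name of the read-out):
- compound 1, `Brc1cn2ccnc2c(-c2ccc3ncn(C4CCCCC4)c3c2)n1`: 10%
- compound 2, `COc1ccc(-c2cn3ccnc3c(-c3ccc4ncn(C5CCCCC5)c4c3)n2)cc1`: 83.2%
- compound 3, `c1ccc2c(-c3cn4ccnc4c(-c4ccc5ncn(C6CCCCC6)c5c4)n3)cccc2c1`: 6.33%

Compound 3 has the lowest value of the three. Its nearest neighbour is compound 1, which is a number 3.7 percentage points lower from compound 1 to compound 3 (within the scatter), a gap within the scatter. The furthest is compound 2: the step of a number 76.9 percentage points lower from compound 2 to compound 3 (beyond the scatter) is large and beyond the scatter.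

Compound 4, `Clc1ccc(-c2cn3ccnc3c(-c3ccc4ncn(C5CCCCC5)c4c3)n2)cc1`, has not yet been measured. Compared with compound 3 the change is 4-chlorophenyl in place of naphthalen-1-yl on an aromatic carbon. The step that bears on it most is a number 76.9 percentage points lower from compound 2 to compound 3 (beyond the scatter), which shows that the naphthalen-1-yl group at this position sits far below a para-substituted phenyl. Compound 4 reverses that exchange, though with a chloro rather than a methoxy group on the phenyl ring, so the size of the return is uncertain. The step of a number 73.2 percentage points higher from compound 1 to compound 2 (beyond the scatter) also shows how large a gain a phenyl group here can bring.

Compound 4 is therefore expected to rise well beyond the scatter, by about a number 48.7 percentage points higher from compound 3 to compound 4 (beyond the scatter). The estimated value of compound 4 in this assay is 55%, with a range from 20% to 85%.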

Compound 4, a percentage reported as inhibition, at one concentration (the size of the read-out at that concentration, not a potency): 12.1%
For compound 4 the middle estimate is 42.9 percentage points above the measured one; measured number outside the range, below it.
By their numbers in this assay, from the lowest: compounds 3, 1 and 4 (each within the scatter of the next); then compound 2.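

In this assay, 4-chlorophenyl at this position does not separate from naphthalen-1-yl (a number 5.8 percentage points higher from compound 3 to compound 4 (within the scatter)) or from bromo (a number 2.1 percentage points higher from compound 1 to compound 4 (within the scatter)), so a phenyl ring at this carbon does not by itself bring the gain seen with 4-methoxyphenyl. The substituent on that ring decides the outcome here: chloro in place of methoxy is a large step (a number 71.1 percentage points lower from compound 2 to compound 4 (beyond the scatter)), and of the four compounds only compound 2 stands apart. Nothing available explains why this single exchange changes the read-out so strongly.

The compounds shown leave open whether the high value is particular to methoxy or would also appear with an amine, a hydroxyl or an ethoxy group on the phenyl ring. They also leave open whether methoxy would hold that value at another carbon of the ring.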